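Pyrazole swap on the shared core

This account rests on a few compounds, and the source may have more. Where it says the series, first, only, none or still open, it means among the compounds named here.

Measured in an assay on cells for inhibition of MAP kinase-interacting serine/threonine-protein kinase 1 (Homo sapiens), read by mobility shift assay, with stated times of 10 min and 60 min, in the presence of a further agent that is not named here; a higher number here means a weaker inhibitor, a lower number a stronger inhibitor:
compound 1 `CC(C)Oc1cc(-c2cncc(-c3cnn(C4COC4)c3)c2)ccc1C(N)=O` gives 200 nM
compound 2 `Cc1cc(-c2cccnc2)ccc1C(N)=O` gives 22000 nM

Compound 1 holds the lower of the two numbers; compound 2 sits far above it, and that gap lies beyond the scatter. Within the data shown here, no single step is drawn between compound 1 and compound 2, so only their two values are compared here.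

Compound 3 `Cc1c(-c2cncc(-c3ccc(C(N)=O)c(OC(C)C)c3)c2)cnn1C` has not yet been measured in this assay. It differs from compound 1 by 1,5-dimethyl-1H-pyrazol-4-yl in place of 1-(oxetan-3-yl)-1H-pyrazol-4-yl on an aromatic carbon. The pyrazole is kept, the oxetane is replaced by a methyl and a further methyl is added to the pyrazole. Among the measured compounds shown here, nothing measured so far isolates this part of the structure, so the change is expected to be modest, in either direction, probably within the scatter; the expected step is a 1.5-fold higher number from compound 1 to compound 3 (0.18 log units; within the scatter). Compound 3 is estimated at about 300 nM in this assay, with a range from 80 nM to 1200 nM.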

Compound 3, half-maximal inhibitory concentration in the MAP kinase-interacting serine/threonine-protein kinase 1 assay: 60 nM
Beside the measured number, compound 3's estimate is 5.0-fold (0.70 log units) above it; measured number below the stated range.
By their numbers in the MAP kinase-interacting serine/threonine-protein kinase 1 assay, from the lowest: compound 3; then compound 1; then compound 2.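

In the MAP kinase-interacting serine/threonine-protein kinase 1 assay, placing 1,5-dimethyl-1H-pyrazol-4-yl instead of 1-(oxetan-3-yl)-1H-pyrazol-4-yl on this aromatic carbon gives a 3.3-fold lower number from compound 1 to compound 3 (0.52 log units; beyond the scatter). Among these compounds, this is the first one-place comparison, and it shows that the number responds to the groups carried by the pyrazole, even with the pyrazole kept and its place on the shared core unchanged. In a physicochemical assay for solubility, measured as thermodynamic solubility, at pH 7.4 (a higher number here means a more soluble compound, a lower number a less soluble compound), compound 1 gives 28 ug/mL and compound 3 gives 7.3 ug/mL in the same measurement. The change also comes with a loss in the physicochemical assay: the measured solubility of compound 1, 28 ug/mL, and of compound 3, 7.3 ug/mL, a 3.8-fold lower number (0.58 log units; beyond the scatter)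

The step replaces the oxetane with a methyl and adds a further methyl to the pyrazole in one move, so the shares of these two changes in either result remain unresolved. Also open, as far as these compounds go, is whether an amine on the pyrazole could combine the potency of compound 3 with the solubility of compound 1.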